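This account rests on a few compounds, and the source may have more. Where it says the series, first, only, none or still open, it means among the compounds named here.

Compound 1 `CC1CCN(C(=S)SCc2ccc(C(=O)Nc3ccccc3N)cc2)CC1` is one of three related compounds whose growth-inhibiting effect was measured in a functional assay on MGC-803 cells (Homo sapiens) for antiproliferative activity, read by CCK-8 assay, with a stated time of 72 h, tested at 2 uM; on this read-out higher numbers stand for a stronger effect at the one concentration tested and lower numbers for a weaker effect. In this assay compound 1 gives 28.1%, the largest of the three numbers, although its gaps to both of the others lie within the usual scatter of such measurements. Compound 2 `COc1ccc(N2CCN(C(=S)SCc3ccc(C(=O)Nc4ccccc4N)cc3)CC2)cc1` gives 25.3% in this assay, and compound 3 `Nc1ccccc1NC(=O)c1ccc(CSC(=S)N2CCN(Cc3ccccc3)CC2)cc1` gives 18.1%. Among the compounds with values here, the only measured step that changes a single place, a number 7.2 percentage points lower from compound 2 to compound 3 (within the scatter), exchanges the group on a ring nitrogen that is not the thiocarbonyl carbon's neighbour, and it does not move the number beyond the scatter.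

Compound 4 `Nc1ccccc1NC(=O)c1ccc(CSC(=S)N2CCc3cc(Cl)ccc32)cc1` has not yet been measured. It differs from compound 1 in one place: 5-chloro-2,3-dihydro-1H-indol-1-yl in place of 4-methylpiperidin-1-yl on a thiocarbonyl carbon. Within the data shown here, this exchange replaces the whole ring that is joined to the thiocarbonyl carbon, not merely a group on such a ring, so no measured step matches it closely, and the one step that touches the same region of the shared core stayed within the scatter. On this basis, no step beyond the scatter is expected in this assay. Compound 4 is therefore expected to give about 28% in this assay, somewhere between 14% and 44%. The step this estimate means, a number 0.1 percentage points lower from compound 1 to compound 4 (within the scatter), is expected to stay within the scatter.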

Compound 4, a percentage reported as inhibition, at one concentration (the size of the read-out at that concentration, not a potency): 57.7%
Beside the measured number, compound 4's estimate is 29.7 percentage points below it; the measured number lies above the stated range.
By their numbers in this assay, from the lowest: compounds 3, 2 and 1 (each within the scatter of the next); then compound 4.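

Exchanging the whole ring on the thiocarbonyl carbon, 5-chloro-2,3-dihydro-1H-indol-1-yl in place of 4-methylpiperidin-1-yl, gives in this assay a number 29.6 percentage points higher from compound 1 to compound 4 (beyond the scatter), the only step shown that lies beyond the scatter. Compounds 1, 2 and 3 all lie within the scatter of one another, so they gave no sign that the read-out could respond to a change at this position; compound 4 shows that it can, at least for this one exchange. Nothing at hand shows what about the exchange lies behind the higher number.

The exchange alters several things at once, as the entering group brings a five-membered ring in place of a six-membered one, an aromatic carbon ring and a chlorine, and the compounds shown do not separate these parts. A plain 2,3-dihydro-1H-indol-1-yl group without chlorine, or one carrying bromine or a methoxy group in place of the chlorine, would show how much of the step belongs to the chlorine, while the single tested concentration leaves potency itself open.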